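Tert-butyl Amide Variant of an Inactive Furan Series

This account rests on a few compounds, and the source may have more. Where it says the series, first, only, none or still open, it means among the compounds named here.

Compound 1 `C=CC1=C(C(=O)O)C(c2ccc(F)cc2)OC1` gives > 100000 nM in a functional assay on QGY7701 cells (Homo sapiens) for cytotoxicity, read by MTT assay, with a stated time of 24 h; a higher number here means a weaker inhibitor, a lower number a stronger inhibitor.
Compound 2 `C=CC1=C(C(=O)NC(C)(C)C)C(c2ccc(OC)cc2)OC1` gives > 100000 nM in this assay.
Compound 3 `C=CC1=C(C(=O)NCC(C)C)C(c2ccc(F)cc2)OC1` gives > 100000 nM in this assay.

Each of these three values is a limit of this assay, not a measured number: none of the three compounds reached half-maximal inhibition within the tested range. Compound 3 therefore stands nowhere in particular among the numbers shown; it sits at the same limit as the other two, as summarised by the limit of > 100000 nM in this assay, at which 3 of the 3 values shown sit. Within the data shown here, the only step between compounds that differ in one place, a step that the two limits leave unreadable from compound 1 to compound 3, is unreadable, since both ends are limits.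

Compound 4 `C=CC1=C(C(=O)NC(C)(C)C)C(c2ccc(F)cc2)OC1` is the next compound to be tested. It differs from compound 3 by tert-butyl in place of isobutyl on an amide-type nitrogen. The same tert-butyl amide already appears in compound 2, on a different aryl ring, and compound 2 also gave only a limit. Among the measured compounds shown here, no measured step bears on this change with a readable size, so no step beyond the scatter can be expected in this assay in either direction. Compound 4 is therefore expected to give 200000 nM, with a range from 80000 nM to 500000 nM. The step from compound 3 to compound 4 is estimated as a step that the limit leaves unreadable from compound 3 to compound 4, and the most likely outcome is again only a limit.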

Compound 4, half-maximal inhibitory concentration: > 100000 nM
Compound 4 gave a limit, no number; the forecaster's own chance of this, stated with the estimate: 85%; the middle value does not contradict the limit.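

No size can be read for the steps to compound 4 from compound 1, compound 2 or compound 3, as all four compounds sit at one limit of the assay, not at a measured number: the limit of > 100000 nM in this assay, at which 4 of the 4 values shown sit.

The compounds shown leave open whether swapping the hydroxy, the amide groups, or the fluoro and methoxy changes the result in this assay at all.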